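Working notes: aryl group change on the ring nitrogen

The compounds below may be only part of what the source reports. "The series", "measured", "known", "first", "only" and "open" are said of these compounds alone.

Measured compounds, in an assay on isolated protein for inhibition of Apoptosis regulator Bcl-2 (Homo sapiens), read by fluorescence polarization, with a stated time of 60 min; on this read-out lower numbers stand for stronger inhibition and higher numbers for weaker inhibition:
compound 1 `CCCCc1c(-c2ccc(C(=O)NS(=O)(=O)c3ccc4ccccc4c3)cc2C(=O)N2CCc3ccccc3C2)c(C(=O)OCC)nn1-c1ccc(OC)cc1`: 1790 nM
compound 2 `CCCCc1c(-c2ccc(C(=O)NS(=O)(=O)c3ccc4ccccc4c3)cc2C(=O)N2CCc3ccccc3C2)c(CO)nn1-c1ccc(-c2ccccc2)cc1`: 7 nM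
compound 3 `CCCCc1c(-c2ccc(C(=O)NS(=O)(=O)c3ccc4ccccc4c3)cc2C(=O)N2CCc3ccccc3C2)c(CO)nn1-c1ccc(CCO)cc1`: 20 nM

Compound 3 holds the second highest number of the three, with compound 2 nearest and compound 1 furthest away. Among the measured compounds shown here, the one step that bears on the change in question is a 2.9-fold higher number from compound 2 to compound 3 (0.46 log units; beyond the scatter), a modest shift in this assay when the group on the aromatic nitrogen was altered. Compound 4 `CCCCc1c(-c2ccc(C(=O)NS(=O)(=O)c3ccc4ccccc4c3)cc2C(=O)N2CCc3ccccc3C2)c(CO)nn1-c1cccc(CO)c1` makes a further change at the same place: 3-(hydroxymethyl)phenyl in place of 4-(2-hydroxyethyl)phenyl on an aromatic nitrogen. For the measured compounds named here, with only that one measured step as a guide, a small move in either direction, or none beyond the scatter, is expected. The estimate for compound 4 is 25 nM, range 8 nM to 80 nM, corresponding to an expected step of a 1.3-fold higher number from compound 3 to compound 4 (0.10 log units; within the scatter).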

Compound 4, half-maximal inhibitory concentration: 71 nM
Beside the measured number, compound 4's estimate is 2.8-fold (0.45 log units) below it, within the range that was stated.
By their numbers in this assay, from the lowest: compound 2; then compound 3; then compound 4; then compound 1.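

In this assay, moving to 3-(hydroxymethyl)phenyl on the aromatic nitrogen gives a 3.6-fold higher number from compound 3 to compound 4 (0.55 log units; beyond the scatter), so this position distinguishes between two aryl groups that each carry one hydroxyl. Against 4-phenylphenyl, the same group gives a 10-fold higher number from compound 2 to compound 4 (1.01 log units; beyond the scatter), a larger step than the earlier change to 4-(2-hydroxyethyl)phenyl. No available data explain these differences.

The step from compound 3 to compound 4 alters both substituent location and chain length, so their separate contributions remain unresolved; 4-(hydroxymethyl)phenyl would help divide them. On these data alone, whether an amine or carboxylic acid on this aryl ring fits the same trend also remains open.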